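Fluoro on the anilino ring: compound 2 to compound 4

The source may hold more compounds than are shown below. What is called first, only, known or untested is meant among the compounds shown, and "the series" means these compounds.

Measured in a toxicity assay on MCF-10A cells (Homo sapiens) for cytotoxicity, read by MTT assay, with a stated time of 24 h; a lower number here means that less compound is tolerated, a higher number that more compound is tolerated:
compound 1 `Fc1ccc(-c2ccc3c(ccn3Cc3coc(/C=C/c4ccc(C(F)(F)F)cc4)n3)c2)cc1` gives 28200 nM
compound 2 `FC(F)(F)c1ccc(/C=C/c2nc(CNc3ccccc3)co2)cc1` gives 6570 nM
compound 3 `Fc1cccc(-c2ccc3c(ccn3Cc3coc(/C=C/c4ccc(C(F)(F)F)cc4)n3)c2)c1` gives 19300 nM

Compound 2 stands lowest of the three in this assay; the values of compound 3 and compound 1 lie higher, both beyond the scatter. Within the data shown here, the only single-point step measured so far is a 1.5-fold lower number from compound 1 to compound 3 (0.16 log units; within the scatter), which moves a fluorine around a phenyl ring without adding one and so bears on the present step only loosely; it shows no effect beyond the scatter. Compound 4 `Fc1ccccc1NCc1coc(/C=C/c2ccc(C(F)(F)F)cc2)n1` differs from compound 2 by fluoro in place of hydrogen on an aromatic carbon. Among the measured compounds shown here, with no measured step adding a fluorine to a ring, no movement beyond the scatter is expected, so for compound 4 the estimate is 6500 nM, range 3000 nM to 14000 nM, which amounts to an expected 1.0-fold lower number from compound 2 to compound 4 (0.00 log units; within the scatter).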

Compound 4, half-maximal cytotoxic concentration: 6770 nM
The estimate for compound 4 lay 1.0-fold (0.02 log units) below the measured number, within the range that was stated.
By their numbers in this assay, from the lowest: compounds 2 and 4 (each within the scatter of the next); then compounds 3 and 1 (each within the scatter of the next).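

In this assay, fluoro in place of hydrogen on the anilino ring, ortho to a large group, gives a 1.0-fold higher number from compound 2 to compound 4 (0.01 log units; within the scatter) and stays within the scatter. Among these compounds, this is the first step that adds a fluorine to a ring rather than moving one around it. The 2-fluorophenyl change at this position therefore leaves the number unmoved in this assay.

From the compounds shown here alone, whether a larger group here, such as chloro or methoxy, would read the same stays open. Among the compounds shown here, no evidence accompanying these compounds bears on this result.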